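This account rests on a few compounds, and the source may have more. Where it says the series, first, only, none or still open, it means among the compounds named here.

In an ADME assay on microsomes from liver (Homo sapiens) for metabolic stability, with a stated time of 10 min (on this read-out lower numbers stand for a less stable compound and higher numbers for a more stable compound), compound 2 (`O=C(O)C12CCC(C(=O)N3CC[C@](c4ccc(C(F)(C(F)(F)F)C(F)(F)F)cc4)(S(=O)(=O)c4ccc(F)cc4)C3)(CC1)OC2`) gives 90%, and compound 1 (`CO[C@]1(C(=O)N2CC[C@](c3ccc(C(F)(C(F)(F)F)C(F)(F)F)cc3)(S(=O)(=O)c3ccc(F)cc3)C2)CC[C@H](C(=O)O)CC1`) gives 82%. Within the data shown here, these two results cannot be told apart, so compound 2 stands level with the only other measured compound. The next compound is compound 3 (`NC(=O)[C@H]1CC[C@H](C(=O)N2CC[C@](c3ccc(C(F)(C(F)(F)F)C(F)(F)F)cc3)(S(=O)(=O)c3ccc(F)cc3)C2)CC1`), and the change is a group of 9 heavy atoms (7 carbon, 1 nitrogen, 1 oxygen; one six-membered non-aromatic ring of carbon only) in place of a group of 11 heavy atoms (8 carbon, 3 oxygen; one six-membered non-aromatic ring of carbon only, one six-membered non-aromatic ring with 1 hetero atom), on a carbonyl carbon. The group that enters is 4-carbamoylcyclohexyl, which neither measured compound carries. Among the measured compounds shown here, the one measured step, a number 8 percentage points higher from compound 1 to compound 2 (within the scatter), also exchanges the group on that carbonyl carbon, and it gives the only available guide to a change at this place. It is a weak guide, as it says nothing directly about the entering group. No shift beyond the scatter is therefore expected, and the estimated change is a number 6 percentage points lower from compound 2 to compound 3 (within the scatter). For compound 3 the estimated value is 84%, with an expected range from 62% to 97%.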

Compound 3, percent of the compound remaining: 100%
Compound 3: middle estimate off by 16 percentage points, on the low side, and the stated range ends below it.
By their numbers in this assay, from the lowest: compounds 1, 2 and 3 (each within the scatter of the next, the first and the last beyond it).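

In this assay the step of a number 10 percentage points higher from compound 2 to compound 3 (within the scatter) shows that 4-carbamoylcyclohexyl, with its amide in place of a carboxylic acid, stands level with the group of compound 2 on this carbonyl carbon. Among these compounds, the step of a number 18 percentage points higher from compound 1 to compound 3 (beyond the scatter) is the first change at this position to lie beyond the scatter, so the group on this carbonyl carbon can make a measurable difference to the read-out. That step swaps 4-carboxy-1-methoxycyclohexyl for 4-carbamoylcyclohexyl, which removes the methoxy group and replaces the carboxy group at once, so neither change can be credited alone.

The compounds shown leave open how an unsubstituted cyclohexyl, or a cyclohexyl carrying an amine or a methoxy group together with the carbamoyl group, would behave at this place. No measurement available here accounts for the difference between compound 1 and compound 3.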